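From Fluoro to Bromo at the Assay Limit

The source may report more compounds than this note shows. Statements on the series, on what has been measured and on what is new or still open speak of the compounds shown alone.

In a functional assay on thoracic aorta (Rattus norvegicus, strain Wistar), with a stated time of 15 min (on this read-out lower numbers stand for an effect already at smaller amounts and higher numbers for an effect only at larger amounts of compound), compound 1 `COc1ccc(Br)cc1C(C)NC(=O)NS(=O)(=O)c1ccccc1` gives > 300000 nM, which is a limit of the assay and not a number. Compound 2 `CCOc1ccc(F)cc1C(C)NC(=O)NS(=O)(=O)c1ccccc1` gives > 300000 nM, also only a limit, so it stands where the other value stands: the limit of > 300000 nM in this assay, at which 2 of the 2 values shown sit. Compound 3 `CCOc1ccc(Br)cc1C(C)NC(=O)NS(=O)(=O)c1ccccc1` differs from compound 2 by bromo in place of fluoro on an aromatic carbon, with bromo in place of fluoro on an aromatic carbon, para to an ethoxy group. For the measured compounds named here, no measured step covers this exchange, and no change beyond the scatter is expected in this assay. The expected step is a number no higher from compound 2 to compound 3 (the limit leaves the size open). For compound 3 the estimated value is 300000 nM, within a range of 100000 nM to 600000 nM.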

Compound 3, half-maximal effective concentration: > 300000 nM
Compound 3: a limit, no number; the forecaster's own chance of this, stated with the estimate: 75%; the middle value lies on the limit itself.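

For the compounds shown here, compound 1, compound 2 and compound 3 all give only a limit in this assay, so no step among them can be read. As far as these compounds go, whether bromo in place of fluoro, or methyl in place of hydrogen, changes the read-out at all stays open.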